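Removing the trifluoromethoxy group: compound 4 expected

The compounds below may be only part of what the source reports. "The series", "measured", "known", "first", "only" and "open" are said of these compounds alone.

Three anilino-substituted analogues sharing one core have been measured in a functional assay on HCT-116 cells (Homo sapiens) for antiproliferative activity, read by CCK-8 assay, with a stated time of 72 h, tested at 8 uM; on this read-out lower numbers stand for a weaker effect and higher numbers for a stronger effect at the one concentration tested. Compound 1 `Cc1ccc(Nc2nc(Cl)nc3c2ncn3Cc2ccc(/C=C/C(=O)Nc3ccccc3N)cc2)cc1` gives 15%, compound 2 `Nc1ccccc1NC(=O)/C=C/c1ccc(Cn2cnc3c(Nc4cccc(Cl)c4)nc(Cl)nc32)cc1` gives 15.8%, and compound 3 `Nc1ccccc1NC(=O)/C=C/c1ccc(Cn2cnc3c(Nc4cccc(OC(F)(F)F)c4)nc(Cl)nc32)cc1` gives 5.23%. Compound 3 stands at the low end of the three: the step of a number 10.6 percentage points lower from compound 2 to compound 3 (beyond the scatter) lies beyond the scatter, whereas the step of a number 9.8 percentage points lower from compound 1 to compound 3 (within the scatter) does not, and the step of a number 0.8 percentage points higher from compound 1 to compound 2 (within the scatter) is likewise within the scatter.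

Compound 4 `Nc1ccccc1NC(=O)/C=C/c1ccc(Cn2cnc3c(Nc4ccccc4)nc(Cl)nc32)cc1` differs from compound 3 in one place: hydrogen in place of trifluoromethoxy on an aromatic carbon. For the measured compounds named here, no measured step removes a substituent outright, so the closest guide is the step in which trifluoromethoxy replaced chloro, a number 10.6 percentage points lower from compound 2 to compound 3 (beyond the scatter), a modest fall. Undoing the presence of trifluoromethoxy is therefore expected to return the number toward the level shared by compound 1 and compound 2, which lie within the scatter of each other. A modest rise is expected, a number 7.8 percentage points higher from compound 3 to compound 4 (within the scatter), though it may also fall within the scatter. For compound 4 the estimated value in this assay is 13%, with a range from 4% to 24%.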

Compound 4, a percentage reported as inhibition, at one concentration (the size of the read-out at that concentration, not a potency): 30.9%
Beside the measured number, compound 4's estimate is 17.9 percentage points below it; measured number outside the range, above it.
By their numbers in this assay, from the lowest: compounds 3, 1 and 2 (each within the scatter of the next, the first and the last beyond it); then compound 4.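

In this assay, the plain anilino ring of compound 4 stands clear of all three substituted analogues: hydrogen in place of trifluoromethoxy gives (a number 25.7 percentage points higher from compound 3 to compound 4 (beyond the scatter)), hydrogen in place of chloro gives (a number 15.1 percentage points higher from compound 2 to compound 4 (beyond the scatter)) and hydrogen in place of methyl gives (a number 15.9 percentage points higher from compound 1 to compound 4 (beyond the scatter)). The earlier compounds shown here showed only that 4-methylphenyl and 3-chlorophenyl could not be told apart and that trifluoromethoxy gave a lower number than chloro, whereas the new result shows that each of these three substituents goes with a lower number than phenyl, with no exception among the four compounds. Nothing measured here accounts for the rise, and the data offer no explanation for it.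

From the compounds shown here alone, it remains open whether a fluorine atom, a methoxy group or an amine on the same aromatic carbon would keep the number of compound 4 or lower it, and whether a methyl group there would match the 4-methylphenyl of compound 1. Going by these compounds, with every compound read at one concentration, how their potencies compare also remains open.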